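A new group on the amide nitrogen of compound 3

The compounds below may be only part of what the source reports. "The series", "measured", "known", "first", "only" and "open" are said of these compounds alone.

In a functional assay on blood (Homo sapiens), with a stated time of 60 min, in the presence of a further agent that is not named here (a higher number here means that more compound is needed for the effect, a lower number that less compound is needed), compound 1 (`NC(=O)C1(S(=O)(=O)c2ccc(Oc3ccc(OC(F)(F)F)cc3)cc2)CCC2(CCNCC2)C1`) gives 3700 nM and keeps the amide hydrogen. Compound 2 (`CN(C)S(=O)(=O)NC(=O)C1(S(=O)(=O)c2ccc(Oc3ccc(OC(F)(F)F)cc3)cc2)CCC2(CCNCC2)C1`) gives only a limit, > 15000 nM, and no number. Compound 3 (`CS(=O)(=O)NC(=O)C1(S(=O)(=O)c2ccc(Oc3ccc(OC(F)(F)F)cc3)cc2)CCC2(CCNCC2)C1`) also gives only a limit, > 15000 nM, so no exact figure exists for it. This is the limit of > 15000 nM in this assay, at which 2 of the 3 values shown sit, and it leaves compound 3 without a precise place on the scale.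

Compound 4 (`Nc1ccc(F)cc1NC(=O)C1(S(=O)(=O)c2ccc(Oc3ccc(OC(F)(F)F)cc3)cc2)CCC2(CCNCC2)C1`) carries 2-amino-5-fluorophenyl in place of methylsulfonyl on an amide-type nitrogen. Two measured steps change that same nitrogen. One is an at least 4.0-fold higher number from compound 1 to compound 2 (0.60 log units; beyond the scatter) and the other is an at least 4.0-fold higher number from compound 1 to compound 3 (0.60 log units; beyond the scatter), and both are minimum sizes beyond the scatter. The comparison of the two substituted compounds gives no further help, as it is a step that the two limits leave unreadable from compound 2 to compound 3 and cannot be sized. Neither measured step brings in an aromatic ring, so they offer only a loose guide to compound 4.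

Both replacements of the amide hydrogen raised the number, so a reading close to the limit remains the likeliest outcome. For compound 4 the expected change is an at least 1.2-fold lower number from compound 3 to compound 4 (0.09 log units; that floor lies within the scatter), with no shift beyond the scatter anticipated. For compound 4 the estimated value is 12000 nM, within an expected range from 3500 nM to 40000 nM.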

Compound 4, half-maximal effective concentration: > 15000 nM
Compound 4: a limit, no number; the forecaster's own chance of this, stated with the estimate: 55%; middle value at least 1.2-fold (0.09 log units) away from the limit.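

In this assay, placing an aromatic ring on this amide-type nitrogen gives an at least 4.0-fold higher number from compound 1 to compound 4 (0.60 log units; beyond the scatter), so the change away from the amide hydrogen raises the number with a ring as well as with the two sulfonyl groups. Compound 4 gives > 15000 nM, which is a limit of the assay and not a number. The steps among compound 2, compound 3 and compound 4 cannot be read, so these three replacements cannot be ranked, and all that can be said is that each ends at the same limit: the limit of > 15000 nM in this assay, at which 3 of the 4 values shown sit.

As far as these compounds go, it stays open whether any group on this nitrogen can keep the reading near that of compound 1, which gives 3700 nM, since a small chain such as methyl or ethyl would test this with neither a sulfonyl group nor a ring present. A plain phenyl, without the amino group and the fluorine, would also help to separate the effect of the ring itself from that of its two substituents, and only a compound that reads below the limit could give a step of measurable size.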